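This account rests on a few compounds, and the source may have more. Where it says the series, first, only, none or still open, it means among the compounds named here.

Four compounds built on one shared core are followed in an ADME assay on KB cells (Homo sapiens) for cytotoxicity, with a stated time of 48 h; on this read-out lower numbers stand for stronger inhibition and higher numbers for weaker inhibition. Compound 1 `C=C1[C@H](C)CCC[C@]1(C)CC/C(C)=C/CC1=C(O)C(=O)C=C(N[C@@H](C(=O)O)[C@H](C)O)C1=O` and compound 2 `C=C1[C@H](C)CCC[C@]1(C)CC/C(C)=C/CC1=C(O)C(=O)C=C(N[C@H](C(=O)O)C(C)C)C1=O` differ only in 1-carboxy-2-hydroxypropyl in place of 1-carboxy-2-methylpropyl on an amine nitrogen. In this assay compound 1 gives a limit rather than a number, > 10 ug/mL. Compound 2 likewise returns only a limit, > 10 ug/mL. The result is a step that the two limits leave unreadable from compound 2 to compound 1. Compound 3 `CC1=CCC[C@](C)(CC/C(C)=C/CC2=C(O)C(=O)C=C(N[C@H](C(=O)O)C(C)C)C2=O)[C@@H]1C` differs from compound 2 in a group of 9 heavy atoms (9 carbon; one six-membered non-aromatic ring of carbon only) in place of a group of 9 heavy atoms (9 carbon; one six-membered non-aromatic ring of carbon only), on a saturated chain carbon, two bonds along the chain from a double-bonded chain carbon. Compound 3 too reaches only a limit, > 10 ug/mL. Hence a step that the two limits leave unreadable from compound 2 to compound 3, because of the limit of > 10 ug/mL in this assay, at which 3 of the 3 values shown sit. Compound 4 `CC1=CCC[C@](C)(CC/C(C)=C/CC2=C(O)C(=O)C=C(N[C@@H](C(=O)O)[C@H](C)O)C2=O)[C@@H]1C` has not yet been measured; it differs from compound 3 in 1-carboxy-2-hydroxypropyl in place of 1-carboxy-2-methylpropyl on an amine nitrogen, the same change as from compound 2 to compound 1. Compound 4 is expected to show a step that the limit leaves unreadable from compound 3 to compound 4, a guess resting on a step that the two limits leave unreadable from compound 2 to compound 1. Compound 4 is therefore estimated at 20 ug/mL, somewhere between 10 ug/mL and 60 ug/mL.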

Compound 4, half-maximal inhibitory concentration: > 10 ug/mL
Compound 4: a limit, no number; the forecaster's own chance of this, stated with the estimate: 85%; the middle value is on the limit's open side.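

Compound 4 gives > 10 ug/mL, a limit and not a number, so its steps from compound 3 and from compound 1 cannot be read: the limit of > 10 ug/mL in this assay, at which 4 of the 4 values shown sit. The compounds shown leave open how far any of the four lies past that limit, and whether either change shifts the read-out at all.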